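The source may hold more compounds than are shown below. What is called first, only, known or untested is meant among the compounds shown, and "the series" means these compounds.

Measured so far in a functional assay on HL-60 cells (Homo sapiens) for antiproliferative activity, read by MTT assay (on this read-out lower numbers stand for stronger inhibition and higher numbers for weaker inhibition), for this series
Compound 1 `C#CC[C@@H]1O[C@H](COCc2ccccc2)[C@@H](OCc2ccccc2)[C@H](OCc2ccccc2)[C@H]1O` gives "not active" (no number reported)
Compound 2 `CCC[C@@H]1O[C@H](COCc2ccccc2)[C@@H](OCc2ccccc2)[C@H](OCc2ccccc2)[C@H]1O` gives 11700 nM

Within the data shown here, compound 2 at 11700 nM carries the only number in this assay so far, while compound 1 has none. Compound 3 `CC(C)C[C@@H]1O[C@H](COCc2ccccc2)[C@@H](OCc2ccccc2)[C@H](OCc2ccccc2)[C@H]1O` differs from compound 2 by methyl in place of hydrogen on a saturated chain carbon bound to two saturated chain carbons in the form of methyl in place of hydrogen on a saturated chain carbon bound to two saturated chain carbons, turning propyl into isobutyl. Among the measured compounds shown here, no measured step informs this change, so no shift beyond the scatter is expected in this assay in either direction. The estimated step of a 1.2-fold lower number from compound 2 to compound 3 (0.07 log units; within the scatter) is small. For compound 3 the estimated value is 10000 nM with an expected range of 4000 nM to 25000 nM around it.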

Compound 3, half-maximal inhibitory concentration: 8500 nM
Beside the measured number, compound 3's estimate is 1.2-fold (0.07 log units) above it, and the stated range covers the measured number.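

In this assay, among these compounds, turning propyl into isobutyl gives a 1.4-fold lower number from compound 2 to compound 3 (0.14 log units; within the scatter) and so gives the series its only measured step at this position. It shows that methyl in place of hydrogen on a saturated chain carbon bound to two saturated chain carbons leaves compound 2 and compound 3 within the usual scatter of each other. No measured evidence bears on this result.

What the compounds shown leave open is whether a longer chain, a phenyl ring or an amine in place of the isobutyl would keep the number in this range.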